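A Larger Ester Group on a Tolerated Compound

The compounds below may be only part of what the source reports. "The series", "measured", "known", "first", "only" and "open" are said of these compounds alone.

Among the compounds with values here, in an ADME assay on H1-HeLa cells (Homo sapiens) for cytotoxicity, read by MTT assay, with a stated time of 3 days (a lower number here means that less compound is tolerated, a higher number that more compound is tolerated), compound 2 `CNC(=O)c1cc(Oc2ccc3ccc(C(=O)OC)cc3c2)ccn1` gives 53500 nM, the only true number available so far. Compound 1 `CCOC(=O)c1cc2ccc(Oc3ccnc(C(=O)NC)c3)c(Cl)c2s1` gives > 100000 nM, which is a limit of the assay and not a number. Within the data shown here, that leaves compound 2 with nothing exact to be ranked against, and no two measured compounds differ in just one place, so no measured step can serve as a guide.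

Compound 3 `CNC(=O)c1cc(Oc2ccc3ccc(C(=O)Oc4ccccc4)cc3c2)ccn1` keeps the core of compound 2 but has phenyl in place of methyl on an oxygen next to a carbonyl group, so methoxycarbonyl becomes phenoxycarbonyl. The change is larger in counted atoms than in hydrogen-bond donors or acceptors, of which it adds none.

In this assay, only a small shift is expected. The estimate amounts to a 1.5-fold lower number from compound 2 to compound 3 (0.18 log units; within the scatter), an expected step that leans towards less compound being tolerated but stays within the usual scatter. For compound 3 the estimated value is 35000 nM, with an expected range from 10000 nM to 100000 nM.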

Compound 3, half-maximal cytotoxic concentration: > 100000 nM
Compound 3 gave a limit, no number; the forecaster's own chance of this, stated with the estimate: 20%; at least 2.8-fold (0.45 log units) between middle value and limit.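

Within the data shown here, replacing methyl with phenyl on an oxygen next to a carbonyl group gives the first comparison in this assay between two compounds that differ in one place, with an at least 1.8-fold higher number from compound 2 to compound 3 (0.27 log units; that floor lies within the scatter). That floor lies within the scatter, so this result alone does not establish that the change moves the value, but it does show that adding the six-membered aromatic ring at this position produced no measured sign of less compound being tolerated. The true size of the step remains unknown because the reading for compound 3 is a limit and not a number: the limit of > 100000 nM in this assay, at which 2 of the 3 values shown sit.

The compounds shown leave open how this position would respond to a butyl chain, or to a phenyl ring carrying an amine, and so whether the result with phenyl extends to other groups on this oxygen. They also cannot rank compound 1 against compound 3, since those two differ in more than one place and neither has an exact number to compare.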